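This account rests on a few compounds, and the source may have more. Where it says the series, first, only, none or still open, it means among the compounds named here.

In a functional assay on MCF7 cells (Homo sapiens) for inhibition, read by CCK-8 assay, with a stated time of 48 h (a higher number here means a weaker inhibitor of growth, a lower number a stronger inhibitor of growth), compound 1 (`Cc1ccccc1Nc1nc(NC2CC2)ncc1Cl`) gives > 100000 nM, which is a limit of the assay and not a number. Compound 2 (`Cc1ccccc1Nc1nc(NC2CCCCC2)ncc1Cl`) gives > 100000 nM, which is also a limit. Among the compounds with values here, the only measured step is a step that the two limits leave unreadable from compound 1 to compound 2, where cyclohexyl takes the place of cyclopropyl, so it offers no size to carry forward. Both compounds therefore stand at the limit of > 100000 nM in this assay, at which 2 of the 2 values shown sit.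

Compound 3 (`Cc1ccccc1Nc1nc(Nc2ccccc2)ncc1Cl`) keeps the core of compound 1 and changes one group, from cyclopropylamino to anilino: phenyl in place of cyclopropyl on a nitrogen on an aromatic ring. Within the data shown here, with a step that the two limits leave unreadable from compound 1 to compound 2 as the only precedent, any expectation is loose. A modest move towards stronger growth inhibition, meaning a lower number in this assay, is expected, though the reading may well stay at the limit. The expected change is an at least 1.6-fold lower number from compound 1 to compound 3 (0.22 log units; that floor lies within the scatter). Compound 3 is estimated at 60000 nM, with an expected range of 15000 nM to 100000 nM.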

Compound 3, concentration for 50% growth inhibition: > 100000 nM
Compound 3 was reported as a limit (the forecaster's own chance of this, stated with the estimate: 55%); middle value at least 1.6-fold (0.22 log units) from the limit.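

In this assay compound 3 gives > 100000 nM (a limit of the assay, not a number), so its steps from compound 1 and compound 2 cannot be read. The compounds shown leave open how cyclopropyl, cyclohexyl and phenyl on this nitrogen truly rank against one another.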